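Ester capping of the acid in a benzothiazole hydrazide series

The source may hold more compounds than are shown below. What is called first, only, known or untested is meant among the compounds shown, and "the series" means these compounds.

Three compounds have numbers in a functional assay on MCF7 cells (Homo sapiens) for inhibition, read by MTT assay, with a stated time of 3 days; a lower number here means a stronger inhibitor, a higher number a weaker inhibitor. Compound 1 `COc1cc(-c2nc3ccccc3s2)ccc1OCC(=O)NNC(=O)CN(C(C)=O)[C@@H](CS)C(=O)O` gives 1750 nM in this assay. Compound 3 `CCOC(=O)[C@H](CS)N(CC(=O)NNC(=O)COc1ccc(-c2nc3ccccc3s2)cc1OC)C(C)=O` gives 1890 nM in this assay. Compound 2 `COc1cc(-c2nc3ccccc3s2)ccc1OCC(=O)NNC(=O)CNC(=N)NCCC[C@H](N[N+](=O)[O-])C(=O)O` gives 1960 nM in this assay. All three numbers sit within the usual scatter of one another, so no order among them is claimed.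

The change from compound 1 to compound 3 is ethyl in place of hydrogen on an oxygen next to a carbonyl group, and it gave a 1.1-fold higher number from compound 1 to compound 3 (0.03 log units; within the scatter). The difference between the core of compound 1 and the core of compound 2 is not broken down here; their two values merely sit close together.

Compound 4 `CCOC(=O)[C@H](CCCNC(=N)NCC(=O)NNC(=O)COc1ccc(-c2nc3ccccc3s2)cc1OC)N[N+](=O)[O-]` has not yet been measured in this assay. It differs from compound 2 by ethyl in place of hydrogen on an oxygen next to a carbonyl group. The place of the change reads the same as for the pair of compound 1 and compound 3, so this is taken as the same change applied to the other core.

Within the data shown here, the expectation rests on the one measured instance of the change: the step from compound 1 to compound 3 stayed within the scatter, and nothing among the three measured compounds points to the other core answering the change differently. The step from compound 2 to compound 4 is therefore expected to be a 1.1-fold higher number from compound 2 to compound 4 (0.03 log units; within the scatter), again within the scatter. Compound 4 is thus estimated at 2100 nM in this assay, with a likely range from 1100 nM to 4000 nM.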

Compound 4, half-maximal inhibitory concentration: 1950 nM
Beside the measured number, compound 4's estimate is 1.1-fold (0.03 log units) above it; the range from low to high includes it.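

In this assay, ethyl in place of hydrogen on an oxygen next to a carbonyl group gave a 1.0-fold lower number from compound 2 to compound 4 (0.00 log units; within the scatter), so the carboxy to ethoxycarbonyl change reads alike on the two cores: the same change on two cores in this assay, a 1.1-fold higher number (0.03 log units; within the scatter) from compound 1 to compound 3 and a 1.0-fold lower number (0.00 log units; within the scatter) from compound 2 to compound 4, 1.1-fold (0.04 log units) apart, within the scatter of two such steps

Across these two pairs, the change therefore carries from the core of compound 1 to the core of compound 2 with no step beyond the scatter and no sign that the core alters the outcome. This does not show that the change is without effect, since a small real step in either direction on either core could lie hidden within the scatter, and two pairs in a single assay say nothing about a third core, about another assay or about why the numbers stay level.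

The compounds shown leave open whether a longer chain on the same oxygen, such as butyl, or a group carrying a ring, such as benzyl, would also stay within the scatter. They also leave open what a primary amide or a hydroxamic acid in place of the carboxy group would give on either core.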